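Three Analogues Sharing One Core, One Measured So Far

The compounds below may be only part of what the source reports. "The series", "measured", "known", "first", "only" and "open" are said of these compounds alone.

Compound 1 `N#Cc1ccccc1CN1CCC(O)(Cn2cnc3c(cnn3-c3ccc(F)cc3)c2=O)CC1` gives 8100 nM in an assay on Sf21 cells for inhibition of ubiquitin carboxyl-terminal hydrolase 7 (Homo sapiens), read by spectrophotometry, with stated times of 30 min and 2 h; on this read-out lower numbers stand for stronger inhibition and higher numbers for weaker inhibition. Compound 2 `O=c1c2cnn(-c3ccc(F)cc3)c2ncn1CC1(O)CCN(Cc2c(Cl)cccc2Cl)CC1` carries the same core but its result in this assay is "not determined" (no result reported), so it stands without a number. Compound 3 `COC(=O)c1ccc(CN2CCC(O)(Cn3cnc4c(cnn4-c4ccc(F)cc4)c3=O)CC2)c(F)c1` differs from compound 2 by the change (2-fluoro-4-(methoxycarbonyl)phenyl in place of 2,6-dichlorophenyl on a saturated chain carbon bound to an amine nitrogen in a ring). Among the measured compounds shown here, with no measured pair showing this step, its size and direction cannot be read from data; the only anchor is compound 1 at 8100 nM. Compound 3 is therefore expected to land near 5000 nM, within a wide range from 1000 nM to 25000 nM.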

Compound 3, half-maximal inhibitory concentration: 800 nM
The estimate for compound 3 lay 6.3-fold (0.80 log units) above the measured number; measured number outside the range, below it.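

In this assay, the group on the saturated chain carbon bound to an amine nitrogen in a ring proves able to shift the read-out: 2-fluoro-4-(methoxycarbonyl)phenyl in place of 2-cyanophenyl gives a 10-fold lower number from compound 1 to compound 3 (1.01 log units; beyond the scatter) with the rest of the molecule unchanged. Among the compounds shown here, this is the first measured step at this position, and it lies beyond the usual scatter. No supporting measurement accounts for the lower number.

The fluorine and the methoxycarbonyl group enter together, and this single step does not separate them. On these data alone, how a carboxylic acid or an amine in place of the methoxycarbonyl group would read remains open.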